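The compounds below may be only part of what the source reports. "The series", "measured", "known", "first", "only" and "open" are said of these compounds alone.

- compound 1 `CC(C)(C)c1ccc(COc2ccc(-c3cn([C@H]4CCN(C[C@@H]5CO5)C4)c4ncnc(N)c34)cc2)cc1` gives 6970 nM
- compound 2 `Nc1ncnc2c1c(-c1ccc(Oc3ccccc3)cc1)cn2[C@H]1CCN(C[C@@H]2CO2)C1` gives 5480 nM

Both numbers come from a functional assay on Daudi cells (Homo sapiens) for antiproliferative activity (on this read-out higher numbers stand for weaker inhibition and lower numbers for stronger inhibition), and they cannot be ranked. The record shows a 1.3-fold lower number from compound 1 to compound 2 (0.10 log units; within the scatter) in a change of the group on the oxygen alone. Compound 2 therefore stands level with compound 1, and neither is ahead.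

Compound 3 `CC(C)(C)c1ccc(Oc2ccc(-c3cn([C@H]4CCN(C[C@@H]5CO5)C4)c4ncnc(N)c34)cc2)cc1` is compound 2 with one change, tert-butyl in place of hydrogen on an aromatic carbon, para to a large group: tert-butyl in place of hydrogen on an aromatic carbon. Phenyl thus becomes 4-(tert-butyl)phenyl. Among the measured compounds shown here, no measured pair shows this exact change, so the evidence is indirect and rests on a single step. Going by a 1.3-fold lower number from compound 1 to compound 2 (0.10 log units; within the scatter) as the only guide, a step that left out a group carrying tert-butyl, no shift beyond the scatter is expected in this assay in either direction. The estimated change is a 1.1-fold higher number from compound 2 to compound 3 (0.04 log units; within the scatter) and it could fall either way. The expected value for compound 3 is 6000 nM with 2500 nM to 14000 nM as its estimated range.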

Compound 3, half-maximal inhibitory concentration: 6490 nM
The estimate for compound 3 lay 1.1-fold (0.03 log units) below the measured number; the range from low to high includes it.
By their numbers in this assay, from the lowest: compounds 2, 3 and 1 (each within the scatter of the next).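

In this assay, the change from phenoxy to 4-(tert-butyl)phenoxy gives a 1.2-fold higher number from compound 2 to compound 3 (0.07 log units; within the scatter), so a tert-butyl group on this aromatic carbon, para to a large group, produces no shift that can be told apart from the scatter of repeated measurements. The new compound also allows a second comparison: 4-(tert-butyl)phenyl in place of 4-(tert-butyl)benzyl on the oxygen gives a 1.1-fold lower number from compound 1 to compound 3 (0.03 log units; within the scatter), which means that compounds 1, 2 and 3 cannot be ranked against one another, whether tert-butyl is present or not and whichever of these groups sits on the oxygen. No independent measurement is available to explain why these numbers stay so close.

Going by these compounds, whether an amine or a carboxylic acid in place of tert-butyl at this same position would move the number beyond the scatter remains open. On these data alone, all three compounds also share the same core and the same group on its nitrogen-containing side, so it is equally open how much any change there would matter in this assay.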